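Replacing 3,4-dichlorophenyl with 3-hydroxyphenyl in compound 3

The compounds below may be only part of what the source reports. "The series", "measured", "known", "first", "only" and "open" are said of these compounds alone.

Measured in a functional assay on HT-29 cells (Homo sapiens) for antiproliferative activity, read by MTT assay, with a stated time of 24 h; on this read-out lower numbers stand for stronger inhibition and higher numbers for weaker inhibition:
Compound 1 `COc1cccc(/C=C/C(=O)c2ccc(OC)c3c2OC(C)(C)C=C3)c1`: > 10000 nM (a limit)
Compound 2 `COc1ccc(C(=O)/C=C/c2cccc(F)c2)c2c1C=CC(C)(C)O2`: > 10000 nM (a limit)
Compound 3 `COc1ccc(C(=O)/C=C/c2ccc(Cl)c(Cl)c2)c2c1C=CC(C)(C)O2`: 7580 nM

Compound 3 alone gives a number, 7580 nM. Compound 1 and compound 2 stand at the limit of > 10000 nM in this assay, at which 2 of the 3 values shown sit. Compound 4 `COc1ccc(C(=O)/C=C/c2cccc(O)c2)c2c1C=CC(C)(C)O2` differs from compound 3 as follows: 3-hydroxyphenyl in place of 3,4-dichlorophenyl on a double-bonded chain carbon bound to a double-bonded chain carbon. Among the compounds with values here, two measured steps bear on this change: an at least 1.3-fold lower number from compound 1 to compound 3 (0.12 log units; that floor lies within the scatter) and an at least 1.3-fold lower number from compound 2 to compound 3 (0.12 log units; that floor lies within the scatter). Each brings in the 3,4-dichlorophenyl that compound 4 gives up, so a slightly higher number is expected in this assay, but no shift clearly beyond the scatter. The expected step is a 1.5-fold higher number from compound 3 to compound 4 (0.16 log units; within the scatter). The estimate for compound 4 is 11000 nM, with an expected range of 5000 nM to 25000 nM.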

Compound 4, half-maximal inhibitory concentration: > 10000 nM
Compound 4: a limit, no number; the forecaster's own chance of this, stated with the estimate: 60%; the middle value does not contradict the limit.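

Within the data shown here, with 3-hydroxyphenyl in place of 3,4-dichlorophenyl on this double-bonded chain carbon, this assay shows an at least 1.3-fold higher number from compound 3 to compound 4 (0.12 log units; that floor lies within the scatter), so the change loses the only measured number in the set, although that floor stays within the scatter. The steps linking compound 4 to compound 1 and to compound 2 cannot be read, with limits at both ends. Compound 4 joins compound 1 and compound 2 at a limit, not a number: the limit of > 10000 nM in this assay, at which 3 of the 4 values shown sit.

On these data alone, how far these three compounds lie beyond that limit stays open. As far as these compounds go, whether an amine or a carboxylic acid on this phenyl ring would give a measurable number also stays open.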